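The source may hold more compounds than are shown below. What is called first, only, known or untested is meant among the compounds shown, and "the series" means these compounds.

Measured in an ADME assay on SH-SY5Y cells (Homo sapiens) for cytotoxicity, read by MTT assay, with a stated time of 72 h; on this read-out lower numbers stand for stronger inhibition and higher numbers for weaker inhibition:
compound 1 `O=C(CN1CCN(C(=O)c2ccc(Cl)cc2)CC1)N1CCN(CCCc2c[nH]c3ccc(F)cc23)CC1`: 125000 nM
compound 2 `COc1ccc(C(=O)N2CCN(CC(=O)N3CCN(CCCc4c[nH]c5ccc(F)cc45)CC3)CC2)cc1`: 161000 nM
compound 3 `COc1cccc(C(=O)N2CCN(CC(=O)N3CCN(CCCc4c[nH]c5ccc(F)cc45)CC3)CC2)c1`: 79400 nM

Compound 3 is not set apart from every other measured compound: a 1.6-fold lower number from compound 1 to compound 3 (0.20 log units; within the scatter), whereas a 2.0-fold lower number from compound 2 to compound 3 (0.31 log units; beyond the scatter). It therefore stands level with one neighbour and modestly clear of the other.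

Next in the series is compound 4 `O=C(CN1CCN(C(=O)c2cccc(Br)c2)CC1)N1CCN(CCCc2c[nH]c3ccc(F)cc23)CC1`, which has bromo in place of methoxy on an aromatic carbon, meta to a large group: bromo in place of methoxy on an aromatic carbon. Going by the values given here, no bromo compound has been measured yet, so the evidence is indirect. The nearest measured exchange between a halogen and methoxy is a 1.3-fold higher number from compound 1 to compound 2 (0.11 log units; within the scatter), and it stays small. Among the compounds with values here, the only step beyond the scatter is the change from 4-methoxyphenyl to 3-methoxyphenyl, and compound 4 keeps the substituent where compound 3 has it. Taken together, these steps give no reason to expect a change beyond the scatter in this assay, and the direction remains open. The step expected is a 1.1-fold lower number from compound 3 to compound 4 (0.05 log units; within the scatter). Compound 4 is estimated at 70000 nM, with an expected range of 30000 nM to 150000 nM.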

Compound 4, half-maximal inhibitory concentration: 71600 nM
The estimate for compound 4 lay 1.0-fold (0.01 log units) below the measured number; measured number inside the range.
By their numbers in this assay, from the lowest: compounds 4, 3, 1 and 2 (each within the scatter of the next, the first and the last beyond it).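

In this assay, bromo in place of methoxy on this aromatic carbon, meta to a large group, leaves the number within the scatter, a 1.1-fold lower number from compound 3 to compound 4 (0.04 log units; within the scatter), so at this place the two substituents cannot be told apart in this read-out, though they differ in heavy atoms and hydrogen-bond acceptors. A second 3-substituted phenyl now stands modestly clear of the 4-methoxyphenyl compound, a 2.2-fold lower number from compound 2 to compound 4 (0.35 log units; beyond the scatter), matching a 2.0-fold lower number from compound 2 to compound 3 (0.31 log units; beyond the scatter), while the 4-chlorophenyl compound goes against any general split between the two placements, as a 1.7-fold lower number from compound 1 to compound 4 (0.24 log units; within the scatter) stays within the scatter. Nothing available explains why these numbers fall as they do.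

Still open, from the compounds shown here alone, is whether a 4-bromophenyl group on the carbonyl carbon would stand level with compound 4 or with compound 2, since a change of placement alone has so far been read only for methoxy. Also open, going by these compounds, is whether the level seen in this assay would hold for a group of a different kind at this place, such as an amine or a carboxylic acid.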